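Swapping Cyanomethyl for Isopropyl in a Cytotoxic Series

A few compounds are considered here, and "the series" means these few. Any claim that something is new, unique, unknown or untested is made for them only; others in the source may bear on it.

Among the measured compounds shown here, in a functional assay on MES-SA cells (Homo sapiens) for cytotoxicity, read by luminescence and CellTiter-Glo, with a stated time of 72 h (on this read-out lower numbers stand for stronger inhibition and higher numbers for weaker inhibition), compound 2 (`COC[C@H](NC(=O)c1cc(C)on1)C(=O)N[C@@H](CC#N)C(=O)N[C@@H](CC(C)C)C(=O)[C@@]1(C)CO1`) gives 29 nM, the lower of the two numbers measured so far, while compound 1 (`COC[C@H](NC(=O)c1cc(C)on1)C(=O)N[C@@H](CC1CCCCC1)C(=O)N[C@@H](CC(C)C)C(=O)[C@@]1(C)CO1`) gives 210 nM. Compound 3 (`COC[C@H](NC(=O)c1cc(C)on1)C(=O)N[C@H](C(=O)N[C@@H](CC(C)C)C(=O)[C@@]1(C)CO1)C(C)C`) alters compound 2 in one place: isopropyl in place of cyanomethyl on a saturated chain carbon bound to an amide-type nitrogen and a carbonyl carbon.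

For the measured compounds named here, only one measured step bears on this, and it is modest: a 7.2-fold lower number from compound 1 to compound 2 (0.86 log units; beyond the scatter), with cyano in place of cyclohexyl. Compound 3 gives up that nitrile and, like compound 1, carries an all-carbon group, though a different one. Judging from compound 1 at 210 nM, a partial move back towards it is expected, meaning a higher number in this assay. With a single step as evidence, this expectation is loose. The expected change is a 2.6-fold higher number from compound 2 to compound 3 (0.41 log units; beyond the scatter). For compound 3 the estimated value is 75 nM, with an expected range from 25 nM to 220 nM.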

Compound 3, half-maximal inhibitory concentration: 57 nM
Beside the measured number, compound 3's estimate is 1.3-fold (0.12 log units) above it; low and high end bracket the measured number.
By their numbers in this assay, from the lowest: compounds 2 and 3 (each within the scatter of the next); then compound 1.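

In this assay, the nitrile proves not to be required on this saturated chain carbon: the change gives a 2.0-fold higher number from compound 2 to compound 3 (0.29 log units; within the scatter), a step that stays within the usual scatter, so cyanomethyl and isopropyl cannot be told apart here. The earlier gain over compound 1 therefore does not belong to the nitrile alone, since an all-carbon group also gives a 3.7-fold lower number from compound 1 to compound 3 (0.57 log units; beyond the scatter), and this step lies beyond the scatter. Nothing available gives a reason for these differences.

On these data alone, it remains open whether an amine, a carboxylic acid or a longer straight chain on this carbon would stay with isopropyl and cyanomethyl or fall back towards cyclohexylmethyl. The compounds shown also leave open how a single methyl group would behave in the same place.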